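Halide swap on the hydrazone aryl ring of the series

The compounds below may be only part of what the source reports. "The series", "measured", "known", "first", "only" and "open" are said of these compounds alone.

Compound 1 `Clc1ccccc1CSc1nnc(-c2ccncc2)n1-c1ccccc1` and compound 2 `Brc1ccccc1CSc1nnc(-c2ccncc2)n1-c1ccccc1` share a core and differ only in the halogen on the benzyl ring. In a functional assay on MCF7 cells (Homo sapiens) for inhibition, read by MTT assay, with a stated time of 48 h (a lower number here means a stronger inhibitor, a higher number a weaker inhibitor), compound 1 gives 18100 nM and compound 2 gives 16100 nM; the step of a 1.1-fold higher number from compound 2 to compound 1 (0.05 log units; within the scatter) is the change (chloro in place of bromo on an aromatic carbon). Compound 3 `O=C(CSc1nnc(-c2ccncc2)n1-c1ccccc1)N/N=C/c1ccc(Br)cc1` gives 7040 nM in this assay, the lowest of the three numbers; its difference from the core of compound 2 is not broken down here. Compound 4 `O=C(CSc1nnc(-c2ccncc2)n1-c1ccccc1)N/N=C/c1ccc(Cl)cc1` carries the change (chloro in place of bromo on an aromatic carbon). For the measured compounds named here, this is the same kind of change as the one from compound 2 to compound 1, though the place differs: in compound 4 the chloro sits para to a large group, whereas in compound 1 it sits ortho to a large group. Going by the values given here, the only measured instance of the swap lies within the scatter, so only a small step is expected from compound 3 to compound 4, namely a 1.1-fold higher number from compound 3 to compound 4 (0.03 log units; within the scatter), because the earlier step of a 1.1-fold higher number from compound 2 to compound 1 (0.05 log units; within the scatter) was so small. Compound 4 is therefore estimated at 7500 nM in this assay, with a range from 3500 nM to 16000 nM expected.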

Compound 4, half-maximal inhibitory concentration: 9930 nM
Compound 4: the middle estimate sits 1.3-fold (0.12 log units) below what was measured; the measured number falls inside the stated range.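

In this assay, the exchange of 4-bromophenyl for 4-chlorophenyl gives a 1.4-fold higher number from compound 3 to compound 4 (0.15 log units; within the scatter), so the numbers for this pair lie within the scatter of each other. Set beside the same exchange on the other core, the step carries over without a detectable difference: the same change on two cores in this assay, a 1.1-fold higher number (0.05 log units; within the scatter) from compound 2 to compound 1 and a 1.4-fold higher number (0.15 log units; within the scatter) from compound 3 to compound 4, 1.3-fold (0.10 log units) apart, within the scatter of two such steps

This supports treating chloro and bromo as interchangeable in this assay on these two cores only; it does not show that the exchange would behave alike on any other core, and with both steps this small, the two instances, which also sit at different places on their rings, cannot reveal any effect of core or place.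

Groups other than the two halogens remain open at this aryl position, such as a methoxy group, a nitrile, an amine or a carboxylic acid, and any of these could give a larger step. Compound 2 and compound 3 differ in more than one place, so the gap between their numbers cannot be assigned to any single part of the structure.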